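From methoxycarbonyl to ethoxycarbonyl: a small step

The compounds below may be only part of what the source reports. "The series", "measured", "known", "first", "only" and "open" are said of these compounds alone.

Values so far in a toxicity assay on Vero cells (Chlorocebus sabaeus) for cytotoxicity, read by MTT assay; on this read-out lower numbers stand for stronger inhibition and higher numbers for weaker inhibition (lower numbers mean stronger inhibition)
- compound 1 (`COC(=O)NC(=O)c1ccsc1NC(=O)c1ccc(S(=O)(=O)N2CCC2)cc1`) gives 17.5 ug/mL
- compound 2 (`COC(=O)NC(=O)c1ccsc1NC(=O)c1ccc(S(=O)(=O)N2CCCCCC2)cc1`) gives 9.13 ug/mL
- compound 3 (`COC(=O)NC(=O)c1ccsc1NC(=O)c1ccc(S(=O)(=O)NC2CCCCC2)cc1`) gives > 64 ug/mL (a limit)

Among the compounds with values here, compound 1 gives 17.5 ug/mL and sits level with its only numeric neighbour (a 1.9-fold lower number from compound 1 to compound 2 (0.28 log units; within the scatter)). Compound 3 gives > 64 ug/mL as a limit of the assay and not a number.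

Compound 4 (`CCOC(=O)NC(=O)c1ccsc1NC(=O)c1ccc(S(=O)(=O)N2CCC2)cc1`) alters compound 1 in one place, turning methoxycarbonyl into ethoxycarbonyl (methyl in place of hydrogen on a saturated chain carbon bound to an oxygen next to a carbonyl group). That means methyl in place of hydrogen on a saturated chain carbon bound to an oxygen next to a carbonyl group.

Within the data shown here, no measured step touches that place. All of them swap the group on the sulfonyl sulfur, and the two beyond the scatter (an at least 3.6-fold higher number from compound 1 to compound 3 (0.56 log units; beyond the scatter) and an at least 7.0-fold higher number from compound 2 to compound 3 (0.84 log units; beyond the scatter)) end on a limit, so they offer little guidance here. The expectation therefore stays close to compound 1 (17.5 ug/mL), with no step beyond the scatter expected in this assay and no firm direction. The estimated step is small (a 1.2-fold lower number from compound 1 to compound 4 (0.07 log units; within the scatter)). The estimated value for compound 4 is 15 ug/mL (expected range 6.5 ug/mL to 38 ug/mL).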

Compound 4, half-maximal inhibitory concentration: > 64 ug/mL
Compound 4: only a limit was reported; the forecaster's own chance of this, stated with the estimate: 8%; at least 4.2-fold (0.63 log units) between middle value and limit.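

In this assay, within the data shown here, the earlier compounds differed only in the group on the sulfonyl sulfur, whereas here the sulfonyl group stays fixed and a single added methyl turns methoxycarbonyl into ethoxycarbonyl, giving an at least 3.6-fold higher number from compound 1 to compound 4 (0.56 log units; beyond the scatter). Compound 4 gives > 64 ug/mL, which is a limit of the assay and not a number. From the compounds shown here alone, this small change at a position not varied before is therefore enough to move the read-out beyond the scatter, although the full size of the step remains unknown: the limit of > 64 ug/mL in this assay, at which 2 of the 4 values shown sit.

The compounds shown leave open whether a longer chain, such as propoxycarbonyl, would give a value that can be read as a number. They also leave open whether ethoxycarbonyl would have a similar effect with azepan-1-yl on the sulfonyl sulfur.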